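Benzothiophene Acylselenourea Analogue: Expected Growth Inhibition

The source may hold more compounds than are shown below. What is called first, only, known or untested is meant among the compounds shown, and "the series" means these compounds.

Three compounds built around a carbon with a double bond to nitrogen and two amide-type nitrogens have been tested in a functional assay on HT-29 cells (Homo sapiens) for cytotoxicity, read by MTT assay, with a stated time of 72 h; a lower number here means a stronger inhibitor of growth, a higher number a weaker inhibitor of growth. Compound 1 `CS/C(=N\C(=O)c1cc2ccccc2s1)NC(=O)c1cc2ccccc2s1` gives 88200 nM in this assay. Compound 3 `CS/C(=N\C(=O)c1cccs1)NC(=O)c1cccs1` reaches only > 100000 nM in this assay, which is a limit of the assay and not a number. Compound 2 `O=C(/N=C(/NC(=O)c1cccs1)[Se]Cc1ccccc1)c1cccs1` likewise reaches only > 100000 nM in this assay, again a limit rather than a number. How the core of compound 1 differs from the core of compound 3 is not broken down here.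

From compound 3 to compound 2 the change is a group of 8 heavy atoms (7 carbon, 1 selenium; one six-membered aromatic ring of carbon only) in place of a group of 2 heavy atoms (1 carbon, 1 sulfur; no ring), on a carbon with a double bond to nitrogen, and the step is a step that the two limits leave unreadable from compound 3 to compound 2, unreadable because both values sit at the limit of > 100000 nM in this assay, at which 2 of the 3 values shown sit.

Compound 4 `O=C(/N=C(/NC(=O)c1cc2ccccc2s1)[Se]Cc1ccccc1)c1cc2ccccc2s1` carries the same change on the core of compound 1: a group of 8 heavy atoms (7 carbon, 1 selenium; one six-membered aromatic ring of carbon only) in place of a group of 2 heavy atoms (1 carbon, 1 sulfur; no ring), on a carbon with a double bond to nitrogen. Within the data shown here, the step from compound 1 to compound 4 is expected to be a 1.5-fold higher number from compound 1 to compound 4 (0.17 log units; within the scatter), resting on compound 1 giving 88200 nM in this assay, already close to the region where the only measured example of this change gave no readable step. Compound 4 is therefore estimated at 130000 nM, within 45000 nM to 350000 nM.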

Compound 4, concentration for total growth inhibition: > 100000 nM
Compound 4: no number, only a limit; the forecaster's own chance of this, stated with the estimate: 60%; the middle value is on the limit's open side.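

Compound 4 gives > 100000 nM in this assay, which is a limit of the assay and not a number. On the core of compound 1, the group of 8 heavy atoms in place of methylsulfanyl gives an at least 1.1-fold higher number from compound 1 to compound 4 (0.05 log units; that floor lies within the scatter), and this is only a floor, so the true size of the step could lie within the scatter or beyond it. The same change on the core of compound 3 cannot be read, so the two steps cannot be compared and nothing shows whether the change carries the same size from one core to the other, because most values stop at the same limit: the limit of > 100000 nM in this assay, at which 3 of the 4 values shown sit.

The change replaces the sulfur and adds the aromatic ring in one step, so the compounds shown do not separate the two; a methylselanyl or a benzylsulfanyl group on the same carbon would be needed for that. From the compounds shown here alone, whether an amine or a carboxylic acid at that place would give a readable number also stays open.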